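The source may hold more compounds than are shown below. What is called first, only, known or untested is meant among the compounds shown, and "the series" means these compounds.

Measured in a functional assay (blood) for inhibition, with Homo sapiens as the target (on this read-out higher numbers stand for weaker inhibition and lower numbers for stronger inhibition), each entry a limit and not a number:
compound 1 `CC(C)(C)Sc1c(CC(C)(C)C(=O)O)n(Cc2ccc(Cl)cc2)c2ccc(OCc3cc4ccccc4cn3)cc12`: > 3000 nM
compound 2 `Cc1nc2ccc(COc3ccc4c(c3)c(SC(C)(C)C)c(CC(C)(C)C(=O)O)n4Cc3ccc(Cl)cc3)cc2s1`: > 3000 nM
compound 3 `CC(C)(C)Sc1c(CC(C)(C)C(=O)O)n(Cc2ccc(Cl)cc2)c2ccc(OCc3cccnc3)cc12`: > 3000 nM

Compound 3 gives only the limit > 3000 nM. No number sets it apart from the other two compounds, and the whole set stands at the limit of > 3000 nM in this assay, at which 3 of the 3 values shown sit.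

The change to compound 4 `CC(C)(C)Sc1c(CC(C)(C)C(=O)O)n(Cc2ccc(Cl)cc2)c2ccc(OCc3cccc(Cl)n3)cc12` puts 6-chloropyridin-2-yl in place of pyridin-3-yl on a saturated chain carbon bound to an oxygen on an aromatic ring. Three measured steps exchange the group at this same place: a step that the two limits leave unreadable from compound 1 to compound 3, a step that the two limits leave unreadable from compound 1 to compound 2 and a step that the two limits leave unreadable from compound 2 to compound 3. None of them has a readable size. The group entering in compound 4 appears in none of them, so they offer neither a size nor a direction for this change.

No step beyond the scatter can be expected on this evidence in this assay. With compound 3 at > 3000 nM, a further limit is the likeliest report. The estimated a number no higher from compound 3 to compound 4 (the limit leaves the size open) carries no direction from the data. For compound 4 the estimated value is 3000 nM, with an expected range from 800 nM to 10000 nM.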

Compound 4, half-maximal inhibitory concentration: 410 nM
Compound 4: middle estimate off by 7.3-fold (0.86 log units), on the high side; the whole stated range lies above it.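

In this assay, the place on a saturated chain carbon bound to an oxygen on an aromatic ring now shows that the exchanged group can change the read-out: 6-chloropyridin-2-yl in place of pyridin-3-yl gives an at least 7.3-fold lower number from compound 3 to compound 4 (0.86 log units; beyond the scatter). The same group also compares clearly with the two other groups at this place, giving an at least 7.3-fold lower number from compound 2 to compound 4 (0.86 log units; beyond the scatter) in place of 2-methyl-1,3-benzothiazol-6-yl and an at least 7.3-fold lower number from compound 1 to compound 4 (0.86 log units; beyond the scatter) in place of isoquinolin-3-yl. All three sizes are lower bounds, and the steps among compounds 1, 2 and 3 cannot be read, since the values of those compounds are limits: the limit of > 3000 nM in this assay, at which 3 of the 4 values shown sit.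

The change to compound 4 brings in the chlorine and the pyridin-2-yl attachment together, so the compounds shown do not separate the two; plain pyridin-2-yl and 5-chloropyridin-3-yl would bear on that question. From the compounds shown here alone, whether the chlorine itself matters, or another group at the same ring atom would serve equally, also stays open, and 6-methylpyridin-2-yl and 6-methoxypyridin-2-yl are groups that would address it.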